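Cyclohexyl for isobutyl in a low oral bioavailability series

This account rests on a few compounds, and the source may have more. Where it says the series, first, only, none or still open, it means among the compounds named here.

Compound 1, `COc1cccc(-c2c(C)n(Cc3c(F)cccc3F)c(=O)n(C[C@H](C)NCc3ccccc3)c2=O)c1F`: 3%
Compound 2, `COc1cccc(-c2c(C)n(Cc3c(F)cccc3F)c(=O)n(C[C@H](N)CC(C)C)c2=O)c1F`: 6%

Of the compounds shown here, two have been measured in an in vivo ADME assay on the whole organism for pharmacokinetics, with Mus musculus as the target; on this read-out higher numbers stand for higher oral bioavailability and lower numbers for lower oral bioavailability. Compound 1 gives 3%, and compound 2 gives 6%. Among the measured compounds shown here, the two numbers lie within the scatter of each other, as the single measured step shows: a number 3 percentage points higher from compound 1 to compound 2 (within the scatter). Compound 2 is the starting point only in the sense that compound 3 is built from it. It is not set apart from compound 1 on this read-out.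

Compound 3, `COc1cccc(-c2c(C)n(Cc3c(F)cccc3F)c(=O)n(C[C@H](N)C3CCCCC3)c2=O)c1F`, differs from compound 2 in one place: cyclohexyl in place of isobutyl on a saturated chain carbon bound to an amine nitrogen and a saturated chain carbon. For the measured compounds named here, the one measured step, a number 3 percentage points higher from compound 1 to compound 2 (within the scatter), touches the same region of the molecule but exchanges other groups, and it stayed within the scatter. Going by the values given here, no measured step follows the isobutyl-to-cyclohexyl exchange itself, so the data give no direction. On that basis compound 3 is expected to show no step beyond the scatter, no change at the digits printed from compound 2 to compound 3 (within the scatter). The estimate for compound 3 in this assay is 6%, with a range from 1% to 18%.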

Compound 3, oral bioavailability: 11%
Compound 3: middle estimate off by 5 percentage points, on the low side; measured number inside the range.
By their numbers in this assay, from the lowest: compounds 1, 2 and 3 (each within the scatter of the next).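

In this assay, cyclohexyl in place of isobutyl on a saturated chain carbon bound to an amine nitrogen and a saturated chain carbon gives a number 5 percentage points higher from compound 2 to compound 3 (within the scatter) and so shows that this position accepts a six-membered non-aromatic ring of carbon only, with 6 heavy atoms where 4 stood, without a step beyond the scatter. The wider exchange of 1-(benzylamino)ethyl for amino(cyclohexyl)methyl on a saturated chain carbon bound to an aromatic nitrogen gives a number 8 percentage points higher from compound 1 to compound 3 (within the scatter) and likewise stays inside the scatter, so none of the three compounds is set apart from the others on this read-out. No supporting measurement bears on this result.

The compounds shown leave open whether a phenyl or cyclopentyl ring at this position, or a hydroxyl or carboxylic acid on the cyclohexyl ring, would bring a step beyond the scatter. They also leave open how oral bioavailability would respond to an amide in place of the amine on that chain carbon.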